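The source may hold more compounds than are shown below. What is called first, only, known or untested is meant among the compounds shown, and "the series" means these compounds.

Of the compounds shown here, two have been measured in an assay on cell membranes for displacement of a labelled ligand from corticotropin-releasing factor receptor 1 (Rattus norvegicus); on this read-out higher numbers stand for weaker inhibition and lower numbers for stronger inhibition. Compound 1, `CCC(CC)Nc1nc(C)nc2c(-c3c(C)cc(N(C)C)nc3C)c(C)nn12`, gives 25.6 nM. Compound 2, `CCCCN(C)c1nc(C)nc2c(-c3ccc(OC)nc3C)c(C)nn12`, gives 8.1 nM. For the measured compounds named here, on these two numbers compound 2 stands lowest; compound 1 is its only neighbour, and the gap between them lies beyond the usual scatter, so compound 2 is the stronger of the pair.

The next compound is compound 3, `CCCN(CCC)c1nc(C)nc2c(-c3ccc(OC)nc3C)c(C)nn12`. It differs from compound 2 in one place: dipropylamino in place of butyl(methyl)amino on an aromatic carbon. Going by the values given here, no other pair in this set shows a change of this kind, so nothing here tells how such a swap moves the number.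

From compound 2 to compound 3 the step is expected to be a 1.2-fold lower number from compound 2 to compound 3 (0.06 log units; within the scatter), that is, nothing beyond the scatter. Compound 3 is therefore expected to land near 7 nM, with a range from 2.5 nM to 20 nM.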

Compound 3, half-maximal inhibitory concentration: 5.7 nM
For compound 3 the middle estimate is 1.2-fold (0.09 log units) above the measured one, and the stated range covers the measured number.
By their numbers in this assay, from the lowest: compounds 3 and 2 (each within the scatter of the next); then compound 1.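

On the aromatic carbon between two ring nitrogen atoms, replacing butyl(methyl)amino with dipropylamino gives, in this assay, a 1.4-fold lower number from compound 2 to compound 3 (0.15 log units; within the scatter), so the two compounds cannot be told apart. For the compounds shown here, this is the first pair that differs in one place, and it shows that, for these two chains, rearranging the carbons on the amine nitrogen and moving to the slightly larger dipropylamino group leaves the number within the scatter. No measurement here explains why these two groups give such similar numbers.

From the compounds shown here alone, whether the number would stay in this range with a longer chain such as dibutylamino, or with a ring amine such as morpholine, remains open. Going by these compounds, it is also open whether the same swap would behave alike on the differently substituted aromatic group of compound 1.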